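Trading Dimethoxyphenyl for Fluorophenyl on a Shared Core

A few compounds are considered here, and "the series" means these few. Any claim that something is new, unique, unknown or untested is made for them only; others in the source may bear on it.

Compound 1, `Nc1cc(N)c2nc(-c3ccccc3)c(Sc3ccc(F)cc3)nc2c1`, gives < 100000 nM in a functional assay on OVCAR-4 cells (Homo sapiens) for inhibition, read by sulforhodamine B assay, with a stated time of 48 h; a higher number here means that more compound is tolerated, a lower number that less compound is tolerated; that value is a limit of the assay, not a number.
Compound 2, `Nc1cc(N)c2nc(-c3ccccc3)c(Oc3ccc(F)cc3)nc2c1`, gives < 100000 nM in this assay; this too is a limit, not a number.
Compound 3, `COc1ccc(CNc2nc3cc(N)cc(N)c3nc2-c2ccccc2)cc1OC`, gives 52500 nM in this assay.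

Compound 3 thus holds the only number shown; the other two values sit at the limit of < 100000 nM in this assay, at which 2 of the 3 values shown sit. Among the compounds with values here, the single measured step, a step that the two limits leave unreadable from compound 1 to compound 2, is unreadable in size, so no measured step bears on the change to compound 4, `Nc1cc(N)c2nc(-c3ccccc3)c(NCc3ccc(F)cc3)nc2c1`: 4-fluorophenyl in place of 3,4-dimethoxyphenyl on a saturated chain carbon bound to a nitrogen on an aromatic ring. Lacking comparable steps, no step beyond the scatter is expected in this assay. Compound 4 is therefore estimated at 45000 nM, between 15000 nM and 100000 nM, an expected step of a 1.2-fold lower number from compound 3 to compound 4 (0.07 log units; within the scatter).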

Compound 4, concentration lethal to 50% of the cells: 60300 nM
Estimate against measurement, compound 4: 1.3-fold (0.13 log units) below; measured number inside the range.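

Swapping 3,4-dimethoxyphenyl for 4-fluorophenyl on a saturated chain carbon bound to a nitrogen on an aromatic ring gives, in this assay, a 1.1-fold higher number from compound 3 to compound 4 (0.06 log units; within the scatter). This is the only readable step shown, and at this position the read-out does not tell the two aromatic groups apart. The steps linking compound 4 to compound 1 and compound 2 cannot be read, because those two compounds carry a limit of the assay, not a number: the limit of < 100000 nM in this assay, at which 2 of the 4 values shown sit.

Going by these compounds, whether a carboxylic acid or an amine on that ring, or a longer chain carrying the ring, would move the number beyond the scatter stays open.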